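Compound 3: A Non-Aromatic Acid Ring Takes the Benzothiophene's Place

This account rests on a few compounds, and the source may have more. Where it says the series, first, only, none or still open, it means among the compounds named here.

Of the compounds shown here, two sharing one core have been measured in an assay on isolated protein for agonist activity at Bile acid receptor (Homo sapiens), read by FRET, with a stated time of 2 h; a higher number here means a larger maximal response, a lower number a smaller maximal response. Compound 1 `CC(C)c1onc(-c2c(Cl)cccc2Cl)c1COc1ccc(Sc2cccc3sc(C(=O)O)cc23)cc1` gives 72% in this assay, and compound 2 `CC(C)c1onc(-c2c(Cl)cccc2Cl)c1COc1ccc(-c2ccc3sc(C(=O)O)cc3c2)cc1` gives 77%. Compound 2 therefore holds the higher of the two numbers shown, but its nearest neighbour, compound 1, sits within the usual scatter of this assay, so no order between the two can be claimed.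

Compound 3 `CC(C)c1onc(-c2c(Cl)cccc2Cl)c1COc1ccc(-c2ccc3c(c2)CC(C(=O)O)C3)cc1` has not yet been measured. It differs from compound 2 in one place: 2-carboxy-2,3-dihydro-1H-inden-5-yl in place of 2-carboxy-1-benzothiophen-5-yl on an aromatic carbon. The 2-carboxy-1-benzothiophen-5-yl group, carrying a five-membered aromatic ring with one hetero atom, gives way to the 2-carboxy-2,3-dihydro-1H-inden-5-yl group, whose five-membered ring is non-aromatic and of carbon only.

Going by the values given here, no step between measured compounds that differ in a single place is available; compound 1 and compound 2 differ in more than one place. The author expects a small step downward or none beyond the scatter, the expected step from compound 2 to compound 3 being a number 9 percentage points lower from compound 2 to compound 3 (within the scatter). Compound 3 is estimated at 68% in this assay, within an expected range from 45% to 92%.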

Compound 3, largest response reached (Emax), in percent of the reference or control that the assay uses: 75%
Beside the measured number, compound 3's estimate is 7 percentage points below it; low and high end bracket the measured number.
By their numbers in this assay, from the lowest: compounds 1, 3 and 2 (each within the scatter of the next).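

In this assay, the 2-carboxy-2,3-dihydro-1H-inden-5-yl group in place of the 2-carboxy-1-benzothiophen-5-yl group, on an aromatic carbon para to a large group, gives a number 2 percentage points lower from compound 2 to compound 3 (within the scatter), the first single-place step available in this series. At this position, therefore, the maximal response does not separate a five-membered aromatic ring with one hetero atom from a five-membered non-aromatic ring of carbon only, and compound 3, which has no sulfur in this group, still gives 75% in this assay. No other measurement here bears on this result, so the step stands without an explanation.

The compounds shown leave open whether a tetrazole or a primary amide could take the place of the carboxylic acid, which all three compounds carry. They also leave open whether a five-membered ring with a ring nitrogen, as in an indole or an indoline, would give a maximal response in the same range as the two groups compared here.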